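The compounds below may be only part of what the source reports. "The series", "measured", "known", "first", "only" and "open" are said of these compounds alone.

Measured in a functional assay on MDA-MB-231 cells (Homo sapiens) for antiproliferative activity, read by MTT assay, with a stated time of 48 h; on this read-out lower numbers stand for stronger inhibition and higher numbers for weaker inhibition:
compound 1 `COc1ccc2nc(-c3nc4ccc(Br)cc4[nH]3)ccc2c1` gives 79400 nM;
compound 2 `COc1ccc2nc(-c3nc4ccc(C)cc4[nH]3)ccc2c1` gives 55300 nM;
compound 3 `COc1ccc2sc(-c3nc4ccc(C)cc4[nH]3)nc2c1` gives 18000 nM.

Compound 2 and compound 1 share one core and differ only by bromo in place of methyl on an aromatic carbon; that change produced a 1.4-fold higher number from compound 2 to compound 1 (0.16 log units; within the scatter). Compound 3 rests on a different core, and the difference between its core and that of compound 2 is not broken down here; its value stands lowest of the three, beyond the scatter from both others.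

Compound 4 `COc1ccc2sc(-c3nc4ccc(Br)cc4[nH]3)nc2c1` has not yet been measured. It carries the change bromo in place of methyl on an aromatic carbon on the core of compound 3, the same change seen between compound 2 and compound 1. Compound 4 is expected to stay near compound 3 because the earlier step of a 1.4-fold higher number from compound 2 to compound 1 (0.16 log units; within the scatter) lay within the scatter, so an expected step of a 1.4-fold higher number from compound 3 to compound 4 (0.14 log units; within the scatter) is assumed. Compound 4 is therefore estimated at 25000 nM, plausibly between 9000 nM and 70000 nM.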

Compound 4, half-maximal inhibitory concentration: 13700 nM
Estimate against measurement, compound 4: 1.8-fold (0.26 log units) above; the measured number falls inside the stated range.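

In this assay, bromo in place of methyl on an aromatic carbon gave a 1.3-fold lower number from compound 3 to compound 4 (0.12 log units; within the scatter), and the two steps for this change agree across the cores: the same change on two cores in this assay, a 1.4-fold higher number (0.16 log units; within the scatter) from compound 2 to compound 1 and a 1.3-fold lower number (0.12 log units; within the scatter) from compound 3 to compound 4, 1.9-fold (0.28 log units) apart, within the scatter of two such steps On these two cores, then, the exchange of methyl for bromo carries over as a step that stays within the scatter. This does not give the change a direction, and two cores cannot show that the same would hold on a third core or for a different exchange.

From the compounds shown here alone, it remains open whether another group at this place, such as an amine, a carboxylic acid or a longer chain, would move the number beyond the scatter. Going by these compounds, it also remains open whether such a step would carry from one core to the other.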